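Carboxy for Chloro on the Tetrazole Aryl Ring

The source may report more compounds than this note shows. Statements on the series, on what has been measured and on what is new or still open speak of the compounds shown alone.

Compound 3 `CCCCCCCCc1ccc(OCC(=O)Cn2nnnc2-c2ccc(Cl)cc2)cc1` gives 45% in an ADME assay on S9 fraction from liver (Rattus norvegicus) for metabolic stability, read by LC-MS, using NADPH, with a stated time of 30 min (on this read-out lower numbers stand for a less stable compound and higher numbers for a more stable compound), the lowest of the three numbers measured. Compound 2 `CCCCCCCCc1ccc(OCC(=O)Cn2nnc(C(=O)O)n2)cc1` gives 52%, within the scatter of compound 3, while compound 1 `CCCCCCCCc1ccc(OCC(=O)Cn2nnc(-c3ccc(C(=O)OC)cc3)n2)cc1` gives 64%, beyond the scatter above it. Compound 4 `CCCCCCCCc1ccc(OCC(=O)Cn2nnnc2-c2ccc(C(=O)O)cc2)cc1` differs from compound 3 by carboxy in place of chloro on an aromatic carbon. Among the compounds with values here, no measured step repeats this change exactly; the closest is a number 12 percentage points lower from compound 1 to compound 2 (beyond the scatter), where a carboxy also entered and the number fell modestly. A drop of similar size or none beyond the scatter is therefore expected, with little confidence. The step of a number 5 percentage points lower from compound 3 to compound 4 (within the scatter) is estimated to stay within the scatter. Compound 4 is expected to give about 40%, between 25% and 58%.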

Compound 4, percent of the compound remaining: 6%
Compound 4: the middle estimate sits 34 percentage points above what was measured; the measured number lies below the stated range.
By their numbers in this assay, from the lowest: compound 4; then compounds 3 and 2 (each within the scatter of the next); then compound 1.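

In this assay carboxy in place of chloro, para to a large group, gives a number 39 percentage points lower from compound 3 to compound 4 (beyond the scatter) as a large step, whereas the earlier carboxy change gave a number 12 percentage points lower from compound 1 to compound 2 (beyond the scatter) as only a modest one. Within the data shown here, a carboxy at this place on the six-membered ring therefore goes with a far bigger loss than the earlier compounds suggested. Nothing measured here explains the size of this fall.

Going by these compounds, whether the fall comes with carboxy specifically or with any replacement of chloro remains open. A nitrile or a primary amide at this place could help separate the two.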